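This account rests on a few compounds, and the source may have more. Where it says the series, first, only, none or still open, it means among the compounds named here.

Compound 1 (`Cc1nn(-c2ccccc2)c(Oc2ccc(-c3nc4cc(C(=O)O)ccc4[nH]3)cc2)c1/C=N/NC(N)=S`), compound 2 (`Cc1nn(-c2ccccc2)c(Oc2ccc(-c3nc4cc(C(N)=O)ccc4[nH]3)cc2)c1/C=N/Nc1ccc([N+](=O)[O-])cc1`), compound 3 (`Cc1nn(-c2ccccc2)c(Oc2ccc(-c3nc4cc(C(N)=O)ccc4[nH]3)cc2)c1/C=N/NC(N)=O`) and compound 4 (`Cc1nn(-c2ccccc2)c(Oc2ccc(-c3nc4cc(C(N)=O)ccc4[nH]3)cc2)c1/C=N/NC(N)=S`) share one core and differ in the groups attached to it. In a functional assay on HeLa cells (Homo sapiens) for cytotoxicity, read by sulforhodamine B assay, with a stated time of 48 h (on this read-out lower numbers stand for stronger inhibition of growth and higher numbers for weaker inhibition of growth), compound 1 gives 22700 nM and compound 2 gives 11900 nM, two values within the usual scatter of each other. Compound 3 has no place on this scale: its result reads "not determined" (no result reported), so it offers no number to start from. Among the compounds with values here, only one place changes on the way to compound 4. On an amine nitrogen, carbamoyl leaves and a group with no common name enters, with sulfur where the carbamoyl has oxygen: a group of 3 heavy atoms (1 carbon, 1 nitrogen, 1 sulfur; no ring) in place of a group of 3 heavy atoms (1 carbon, 1 nitrogen, 1 oxygen; no ring), on an amine nitrogen. Without a starting value no direction can be given, and no step beyond the scatter is expected in this assay. The nearest guides are two: compound 4 carries the same sulfur-bearing group as compound 1, which gives 22700 nM, and the same groups on the core's far end as compound 2, which gives 11900 nM. Compound 4 is expected at about 16000 nM, with an estimated range of 6000 nM to 40000 nM.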

Compound 4, concentration for 50% growth inhibition: 14600 nM
Compound 4: the middle estimate sits 1.1-fold (0.04 log units) above what was measured, and the stated range covers the measured number.
By their numbers in this assay, from the lowest: compounds 2, 4 and 1 (each within the scatter of the next).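

Compound 4 gives this sulfur-bearing group a number on the shared core with the carbamoyl-bearing far end of compound 2. In this assay amino in place of hydroxy on a carbonyl carbon gives a 1.6-fold lower number from compound 1 to compound 4 (0.19 log units; within the scatter) and stays small, so at this level of growth inhibition that far end can carry either group without a step beyond the scatter. On the amine nitrogen, the sulfur-bearing group in place of the larger group with a six-membered aromatic ring gives a 1.2-fold higher number from compound 2 to compound 4 (0.09 log units; within the scatter) as well, while the change from carbamoyl itself cannot be read, as compound 3 has no number.

Going by these compounds, whether a methyl group or a longer chain on that amine nitrogen would give a step beyond the scatter stays open. No measurement shown here offers an explanation for these values.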